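Cytotoxicity Stays Unread From Compound 3 to Compound 4

The compounds below may be only part of what the source reports. "The series", "measured", "known", "first", "only" and "open" are said of these compounds alone.

All three measured compounds were tested in an ADME assay on HEK293 cells (Homo sapiens) for cytotoxicity, read by CellTiter-Glo and resazurin assay, with a stated time of 72 h (a higher number here means that more compound is needed for the effect, a lower number that less compound is needed), and each of them reaches only the limit of that assay.

Compound 1, `CC(C)N(Cc1cccc(OCCCCCC(=O)O)c1)C(=O)c1ccc(-c2cccc(C(F)(F)F)c2)cc1`: compound 1 gives > 26000 nM, a limit.
Compound 2, `CCOC(=O)CCCCCOc1cccc(CN(C(=O)c2ccc(-c3cccnc3)cc2)C(C)C)c1`: compound 2 gives > 26000 nM, a limit.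
Compound 3, `CCOC(=O)CCCCCOc1cccc(CN(C(=O)c2ccc(-c3cccc(F)c3)cc2)C(C)C)c1`: compound 3 gives > 26000 nM, a limit.

Compound 3 therefore stands at the same limit as the other two measured compounds. For the measured compounds named here, the single one-point step among them, a step that the two limits leave unreadable from compound 2 to compound 3, cannot be sized, as the limit of > 26000 nM in this assay, at which 3 of the 3 values shown sit, makes plain. Compound 4, `CCOC(=O)CCCCCOc1cccc(CN(C(=O)c2ccc(-c3cccc(C(F)(F)F)c3)cc2)C(C)C)c1`, differs from compound 3 by trifluoromethyl in place of fluoro on an aromatic carbon. Going by the values given here, no measured step bears directly on this change. Compound 1, however, already carries the same trifluoromethyl group on that ring, and in this assay compound 1 gives > 26000 nM, a limit. On that ground the step is expected to be a step that the limit leaves unreadable from compound 3 to compound 4, meaning no readable movement beyond the scatter. Compound 4 is accordingly estimated at about 50000 nM, within 20000 nM to 200000 nM, and is most likely to be reported once more only as a limit rather than as a number.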

Compound 4, half-maximal effective concentration: > 26000 nM
Compound 4: a limit, no number; the forecaster's own chance of this, stated with the estimate: 85%; the middle value lies beyond the limit too.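

In this assay compound 4 gives > 26000 nM as a limit. No new step can be read between compound 4 and compound 1, compound 2 or compound 3, because all four stop at the same limit: the limit of > 26000 nM in this assay, at which 4 of the 4 values shown sit.

The compounds shown leave open at what concentration any of them would reach the half-maximal effect, and whether their structural differences change it.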